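This account rests on a few compounds, and the source may have more. Where it says the series, first, only, none or still open, it means among the compounds named here.

Measured so far in an assay on isolated protein for inhibition of alpha-ketoglutarate-dependent dioxygenase alkB homolog 3 (Homo sapiens), read by polymerase chain reaction, with a stated time of 1 h; on this read-out lower numbers stand for stronger inhibition and higher numbers for weaker inhibition:
compound 1 `Cc1[nH]n(-c2nc3cc(C(C)(C)C)ccc3[nH]2)c(=O)c1Cc1ccccc1`, 640 nM
compound 2 `Cc1ccc2[nH]c(-n3[nH]c(C)c(Cc4ccccc4)c3=O)nc2c1`, 670 nM
compound 3 `Cc1[nH]n(-c2nc3cc(C(F)(F)F)ccc3[nH]2)c(=O)c1Cc1ccccc1`, 610 nM

Compound 2 gives the nominally largest of the three numbers, but every pairwise step is within the scatter: a 1.0-fold higher number from compound 1 to compound 2 (0.02 log units; within the scatter) and a 1.1-fold lower number from compound 2 to compound 3 (0.04 log units; within the scatter), with a 1.0-fold lower number from compound 1 to compound 3 (0.02 log units; within the scatter) closing the set. The three measured compounds are therefore indistinguishable in this assay.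

Compound 4 `Cc1ccc2[nH]c(-n3[nH]c(C)c(Cc4ccc(C(F)(F)F)cc4)c3=O)nc2c1` differs from compound 2 by trifluoromethyl in place of hydrogen on an aromatic carbon. All three measured steps exchange a substituent on an aromatic carbon of the shared core, and none of them moved the number beyond the scatter, including the exchange of trifluoromethyl for methyl, a 1.1-fold lower number from compound 2 to compound 3 (0.04 log units; within the scatter). Going by the values given here, no measured step touches the six-membered aromatic ring of carbon only that is changed here, so the bearing of those steps is indirect. On that basis no step beyond the scatter is expected, a 1.0-fold lower number from compound 2 to compound 4 (0.01 log units; within the scatter), and compound 4 is estimated at 650 nM, with a range of 300 nM to 1400 nM.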

Compound 4, half-maximal inhibitory concentration: 570 nM
Estimate against measurement, compound 4: 1.1-fold (0.06 log units) above; low and high end bracket the measured number.
By their numbers in this assay, from the lowest: compounds 4, 3, 1 and 2 (each within the scatter of the next).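

In this assay, trifluoromethyl in place of hydrogen on an aromatic carbon of the six-membered aromatic ring of carbon only, para to a large group, gives a 1.2-fold lower number from compound 2 to compound 4 (0.07 log units; within the scatter) for the series. Among the compounds shown, this is the only change on that ring, so the absence of any step beyond the scatter now covers this position as well as the substituent exchanges in compounds 1, 2 and 3, even with 4 heavy atoms entering in place of hydrogen. Nothing available accounts for this result.

On these data alone, whether an amine, a carboxylic acid or a longer chain at this position would move the number beyond the scatter remains open. No step shown lies beyond the scatter, so the compounds shown give no ranking of substituents at either place.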